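Acyl sulfonamide variation: from compound 3 to compound 4

The compounds below may be only part of what the source reports. "The series", "measured", "known", "first", "only" and "open" are said of these compounds alone.

Of the compounds shown here, three so far have numbers in an assay on isolated protein (Gallus gallus) for inhibition of transmembrane prolyl 4-hydroxylase (Homo sapiens); on this read-out higher numbers stand for weaker inhibition and lower numbers for stronger inhibition. Compound 1 `O=C(O)c1ccc(C(Cc2ccccc2)C(=O)O)cn1` gives 27000 nM. Compound 2 `O=C(O)/C=C/c1ccc(C(=O)O)nc1` gives 10600 nM. Compound 3 `O=C(NS(=O)(=O)c1ccccc1)c1ccc(C(=O)O)nc1` gives 1100 nM, the lowest of the three; its gap to compound 2 and its gap to compound 1 both lie beyond the scatter. Compound 4 `O=C(NS(=O)(=O)c1cc(Br)c(Br)s1)c1ccc(C(=O)O)nc1` has not yet been measured in this assay. It differs from compound 3 in one place: 4,5-dibromothiophen-2-yl in place of phenyl on a sulfonyl sulfur. Going by the values given here, no pair of measured compounds differs in a single place, so no measured step can be carried over to this change. The step expected in this assay is a 1.4-fold lower number from compound 3 to compound 4 (0.14 log units; within the scatter), modest and in no clear direction beyond the scatter. The estimate for compound 4 in this assay is 800 nM, in the range 250 nM to 2500 nM.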

Compound 4, half-maximal inhibitory concentration: 8500 nM
Compound 4: middle estimate off by 11-fold (1.03 log units), on the low side; measured number above the stated range.
By their numbers in this assay, from the lowest: compound 3; then compounds 4 and 2 (each within the scatter of the next); then compound 1.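

In this assay, going by these compounds alone, the step of a 7.7-fold higher number from compound 3 to compound 4 (0.89 log units; beyond the scatter), for 4,5-dibromothiophen-2-yl in place of phenyl on a sulfonyl sulfur, gives the first single-place reading. This position is therefore sensitive to the group it carries, and of these two aromatic rings, phenyl gives the lower number. Nothing measured on these compounds accounts for the rise. Open, going by these compounds, is whether the rise follows the two bromines or the thiophene ring, which thiophen-2-yl without bromine would help separate. Also open, on these data alone, is how a small alkyl group such as methyl would read here.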